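The source may report more compounds than this note shows. Statements on the series, on what has been measured and on what is new or still open speak of the compounds shown alone.

Measured compounds:
Compound 1 `COc1ccc(Oc2ccc3c(NCCCNCc4cc(F)ccc4OC)ccnc3c2)cc1` — in a physicochemical assay for acid dissociation, compound 1 gives 9.28.
Compound 2 `Fc1ccc(-c2ccc3c(NCCCNCc4ccco4)ccnc3c2)cc1` — compound 2 gives 9.47.
Compound 3 `COc1cccc(CNCCCNc2ccnc3cc(CCC(C)C)ccc23)c1O` — compound 3 gives 9.47.

Compound 2 stands level with compound 3 at the digits shown, the two sharing the highest number of the three; compound 1 sits nearest and furthest at once, lower by an amount that remains within the scatter of repeated measurements. Among these three the numbers therefore tell one story: the shared core holds its acid dissociation constant wherever the outer groups vary.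

Compound 4 `Fc1ccc(Cc2ccc3c(NCCCNCc4ccco4)ccnc3c2)c(Cl)c1` has not yet been measured. Compared with compound 2 it carries 2-chloro-4-fluorobenzyl in place of 4-fluorophenyl on an aromatic carbon. Among the measured compounds shown here, no measured pair shows the effect of this kind of change, and the three known values already lie close together, so the account expects no step beyond the scatter in this assay, in neither direction.

For compound 4 the estimate is 9.45, with a range from 9.15 to 9.75; the expected step is a number 0.02 log units lower from compound 2 to compound 4 (within the scatter).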

Compound 4, acid dissociation constant: 9.47
Beside the measured number, compound 4's estimate is 0.02 log units below it; measured number inside the range.
By their numbers in this assay, from the lowest: compounds 1, 2, 3 and 4 (each within the scatter of the next).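

Among the compounds shown here, for the first time in this set, two compounds differ in one place, so this aromatic carbon can be read directly: in this assay the step reads no change at the digits printed from compound 2 to compound 4 (within the scatter) for 2-chloro-4-fluorobenzyl in place of 4-fluorophenyl. The entering group has more heavy atoms and adds a chlorine, yet the step stays within the scatter, so at this position the change leaves the read-out without a visible step. Nothing measured here gives a reason for this result.

The compounds shown leave open whether a carboxylic acid or a primary amine at this same carbon would also stay within the scatter in this assay. They also leave open whether the same change would give the same step on a compound with a different group at the far end of the chain.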